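Adding a Methoxy Group to the Phenyl of Compound 1

The source may hold more compounds than are shown below. What is called first, only, known or untested is meant among the compounds shown, and "the series" means these compounds.

Compound 1 `Cc1cc(NC(=O)Cn2nnc(-c3ccccc3)n2)n(C2CCCCC2)n1` is the starting point. In an assay on HEK293 cells for activation of Kir3.1/Kir3.2 (Homo sapiens), read by thallium flux (on this read-out lower numbers stand for smaller maximal responses and higher numbers for larger maximal responses), compound 1 gives 92% and stands highest of the two plain numbers shown. Compound 3 `O=C(Cn1nnc(-c2ccccc2)n1)Nc1cc(C2CC2)nn1C1CCCCC1` gives 45% in this assay, a step of a number 47 percentage points lower from compound 1 to compound 3 (beyond the scatter). Compound 2 `Cc1cc(NC(=O)Cn2nnc(-c3ccccc3)n2)n(C2CCC(C)(C)CC2)n1` shows only a limit in this assay, namely > 19%, so the step that the limit leaves unreadable from compound 1 to compound 2 cannot be read (the limit of > 19% in this assay, at which 1 of the 3 values shown sits). Compound 4 `COc1cccc(-c2nnn(CC(=O)Nc3cc(C)nn3C3CCCCC3)n2)c1` differs from compound 1 by methoxy in place of hydrogen on an aromatic carbon. For the measured compounds named here, neither measured step touches the phenyl ring, so no step bears directly on this change, and no shift beyond the scatter is expected in this assay; the expected step is a number 7 percentage points lower from compound 1 to compound 4 (within the scatter). Compound 4 is estimated at 85%, between 60% and 100%.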

Compound 4, largest response reached (Emax), in percent of the reference or control that the assay uses: 76%
Estimate against measurement, compound 4: 9 percentage points above; measured number inside the range.
By their numbers in this assay, from the lowest: compound 3; then compound 4; then compound 1.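

Methoxy in place of hydrogen on the phenyl ring changes the response in this assay: the result is a number 16 percentage points lower from compound 1 to compound 4 (beyond the scatter). For the compounds shown here, the phenyl ring, which no earlier step touched, is therefore a place where a small added group can lower the maximal response. Nothing measured here explains this drop. On these data alone, it remains open whether the drop belongs to methoxy itself or would also follow a hydroxyl, an amine or a fluorine at this carbon. As far as these compounds go, the effect of methoxy on the other carbons of the phenyl ring also remains open.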